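Hydroxymethyl shift on the benzyl group: cytotoxicity outlook

The compounds below may be only part of what the source reports. "The series", "measured", "known", "first", "only" and "open" are said of these compounds alone.

In an ADME assay on cells (Peritoneal macrophage, Mus musculus, strain Balb/c) for cytotoxicity, read by resazurin assay, with a stated time of 72 h (a lower number here means that less compound is tolerated, a higher number that more compound is tolerated), compound 1 (`CC1(Cc2ccc([N+](=O)[O-])cc2)CC(S(=O)(=O)c2ccc(F)cc2)=C(c2ccc(/C(N)=N/O)cc2)O1`) gives 97400 nM as a measured number. Compound 2 (`CC1(Cc2ccc(CO)cc2)CC(S(=O)(=O)c2ccc(F)cc2)=C(c2ccc(/C(N)=N/O)cc2)O1`) gives > 100000 nM as a limit of the assay, not a number. Compound 2 thus stands at the limit of > 100000 nM in this assay, at which 1 of the 2 values shown sits, without an exact position. Compound 3 (`CC1(Cc2cccc(CO)c2)CC(S(=O)(=O)c2ccc(F)cc2)=C(c2ccc(/C(N)=N/O)cc2)O1`) has the same atoms joined differently, 3-(hydroxymethyl)phenyl in place of 4-(hydroxymethyl)phenyl on a saturated chain carbon bound to a saturated ring carbon with 3-(hydroxymethyl)phenyl in place of 4-(hydroxymethyl)phenyl on a saturated chain carbon bound to a saturated ring carbon. For the measured compounds named here, the only measured step, an at least 1.0-fold higher number from compound 1 to compound 2 (0.01 log units; that floor lies within the scatter) for hydroxymethyl in place of nitro on an aromatic carbon, is a different change and bears on this one only loosely. No shift beyond the scatter is therefore expected in this assay in either direction. The estimated step is a step that the limit leaves unreadable from compound 2 to compound 3 for this pair. Compound 3 is expected at 105000 nM within an estimated range from 60000 nM to 180000 nM. Compound 3 may again give only a limit of the assay.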

Compound 3, half-maximal cytotoxic concentration: > 100000 nM
Compound 3 ended at the assay's limit (the forecaster's own chance of this, stated with the estimate: 65%); the middle value lies beyond the limit too.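

In this assay, 3-(hydroxymethyl)phenyl in place of 4-(hydroxymethyl)phenyl on a saturated chain carbon bound to a saturated ring carbon leaves the read-out at the limit of the assay, so the step from compound 2 to compound 3 cannot be read. With 3-(hydroxymethyl)phenyl in place of 4-nitrophenyl at that same place, the comparison gives an at least 1.0-fold higher number from compound 1 to compound 3 (0.01 log units; that floor lies within the scatter), so no shift beyond the scatter is shown. Both placements of the hydroxymethyl group therefore read alike only as far as the assay reaches: the limit of > 100000 nM in this assay, at which 2 of the 3 values shown sit.

From the compounds shown here alone, whether compound 2 and compound 3 differ beyond the limit stays open. Also open, going by these compounds, is how an amine or a carboxylic acid in place of the hydroxymethyl group would read in this assay.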